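Trimming the Chain Carbon Group on a Shared Core

The source may report more compounds than this note shows. Statements on the series, on what has been measured and on what is new or still open speak of the compounds shown alone.

Of the compounds shown here, two have been measured in a functional assay on the whole organism with Mus musculus as the target; a higher number here means a larger maximal response, a lower number a smaller maximal response. Compound 1 `CC1(C)O[C@@H]2[C@H](O1)[C@@H](CO)O[C@H]2n1c(=O)n(C/C=C/c2ccccc2)c2c(O)nc(N)nc21` gives 10% in this assay, while compound 2 `CCCCCCCCCCn1c(=O)n(C2OC(CO)[C@@H](O)[C@H]2O)c2nc(N)nc(O)c21` gives 0%. Compound 1 holds the higher of the two numbers, yet its distance to compound 2 lies within the usual scatter, so the two values cannot be told apart and neither compound can be called the more active one.

Compound 3 `Cn1c(=O)n([C@@H]2O[C@H](CO)[C@H]3OC(C)(C)O[C@H]32)c2nc(N)nc(O)c21` has not yet been measured in this assay. It differs from compound 1 in one place: hydrogen in place of 2-phenylethenyl on a saturated chain carbon bound to an aromatic nitrogen. Going by the values given here, no step between measured compounds is available to show what such a change does, so the expectation rests on the two small numbers alone. Among the compounds with values here, both compounds measured so far sit near the bottom of the scale, and compound 3 is expected to stay there too, with a step from compound 1 of a number 5 percentage points lower from compound 1 to compound 3 (within the scatter) that is not expected to exceed the scatter. For compound 3 the estimated maximal response is 5%, within a range from 0% to 20%.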

Compound 3, largest response reached (reported as maximal response), in percent of the reference or control that the assay uses: 17%
The estimate for compound 3 lay 12 percentage points below the measured number; measured number inside the range.
By their numbers in this assay, from the lowest: compounds 2, 1 and 3 (each within the scatter of the next, the first and the last beyond it).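

Hydrogen in place of 2-phenylethenyl on a saturated chain carbon bound to an aromatic nitrogen, which reads as methyl in place of 3-phenylprop-2-en-1-yl, gives in this assay a number 7 percentage points higher from compound 1 to compound 3 (within the scatter), so compound 1 and compound 3 cannot be told apart. Going by these compounds alone, this is the first step read at this position, and it shows that removing the 8 carbon atoms, the aromatic ring and the double bond of the 2-phenylethenyl group does not move the response beyond the scatter. Nothing available explains this result.

Going by these compounds, it remains open whether an amine or a carboxylic acid at this position would give a response beyond the scatter of compound 3. The same is open for a propyl chain, which would separate the effect of chain length from that of the aromatic ring.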